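Swapping a methyl for a methoxy on the aryl amine

A few compounds are considered here, and "the series" means these few. Any claim that something is new, unique, unknown or untested is made for them only; others in the source may bear on it.

Of the compounds shown here, three sharing one core have been tested in a functional assay on MCF7 cells (Homo sapiens) for inhibition, read by sulforhodamine B assay; a lower number here means a stronger inhibitor, a higher number a weaker inhibitor. Compound 1 `Cc1ccc(NC2=CC(=O)c3nc4n(c3C2=O)[C@H]2OC[C@@H](O)[C@H]2OC4)cc1` carries a (4-methylphenyl)amino group and in this assay compound 1 gives 1660 nM. Compound 2 `O=C1C(NC2CCCC2)=CC(=O)c2c1nc1n2[C@H]2OC[C@@H](O)[C@H]2OC1` carries a cyclopentyl group on the amine nitrogen, and its result in this assay is only a limit, > 16000 nM. Compound 3 `CCOc1ccccc1NC1=CC(=O)c2c(nc3n2[C@H]2OC[C@@H](O)[C@H]2OC3)C1=O` carries a 2-ethoxyphenyl group on the same nitrogen, and its result in this assay is also a limit, > 4000 nM. Among the measured compounds shown here, the one change between measured compounds, a step that the two limits leave unreadable from compound 2 to compound 3, therefore cannot be sized, since both ends sit at a limit (the limit of > 16000 nM in this assay, at which 1 of the 3 values shown sits, and (the limit of > 4000 nM in this assay, at which 1 of the 3 values shown sits)). Among the three, compound 1 holds the only value that is an actual number.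

Compound 4 `COc1ccc(NC2=CC(=O)c3nc4n(c3C2=O)[C@H]2OC[C@@H](O)[C@H]2OC4)cc1` differs from compound 1 in one place: methoxy in place of methyl on an aromatic carbon. For the measured compounds named here, no measured step involves this change, so the expectation rests on the change itself being small. Methoxy in place of methyl on an aromatic carbon is expected to move the value in this assay by no more than the usual scatter, in either direction, with the estimated step from compound 1 to compound 4 being a 1.2-fold higher number from compound 1 to compound 4 (0.08 log units; within the scatter). Compound 4 is accordingly expected to give 2000 nM in this assay, within a range from 700 nM to 6000 nM.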

Compound 4, half-maximal inhibitory concentration: 5420 nM
For compound 4 the middle estimate is 2.7-fold (0.43 log units) below the measured one, and the stated range covers the measured number.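

With methoxy in place of methyl on the aromatic carbon para to a large group, this assay shows a 3.3-fold higher number from compound 1 to compound 4 (0.51 log units; beyond the scatter). Among the compounds shown here, this is the first step that can be sized, as the earlier comparison rested on two limits, and it shows that this place on the ring is not indifferent to a change: even a swap this small, with the rest of the molecule untouched, leaves compound 4 a weaker inhibitor than compound 1 by more than the usual scatter. Nothing shown here accounts for the size or direction of this step.

The compounds shown leave open how the same place on the ring would respond to other groups, such as a fluorine, a hydroxyl, a dimethylamino group or a longer chain like propyl, so a single step cannot yet be read as a trend. Also open, going by these compounds, is whether methoxy on a different carbon of the same ring would give a step of similar size or one in the opposite direction.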